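Bromomethyl in place of ethoxycarbonyl: an expected cytotoxicity step

The source may report more compounds than this note shows. Statements on the series, on what has been measured and on what is new or still open speak of the compounds shown alone.

Measured in a functional assay on MDA-MB-231 cells (Homo sapiens) for cytotoxicity, read by MTT assay, with a stated time of 72 h (a higher number here means that more compound is needed for the effect, a lower number that less compound is needed), so far:
compound 1 `CCc1cccc2c(O)c(-c3occ(C)c3C(=O)O)ccc12` gives 0.3 ug/mL
compound 2 `CCOC(=O)c1c(C)coc1-c1ccc2c(CC)cccc2c1OC` gives 3.9 ug/mL
compound 3 `CCc1cccc2c(OC(C)=O)c(-c3occ(C)c3COC(C)=O)ccc12` gives > 10 ug/mL as a limit of the assay

Of the two true numbers in this assay compound 2 at 3.9 ug/mL is the higher, and compound 1 at 0.3 ug/mL lies below it by more than the usual scatter. Compound 3 stands at > 10 ug/mL and that is a limit.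

Compound 4 `CCc1cccc2c(OC)c(-c3occ(C)c3CBr)ccc12` has not yet been measured. It differs from compound 2 by bromomethyl in place of ethoxycarbonyl on an aromatic carbon, two ring bonds from the ring oxygen. Going by the values given here, no measured pair isolates this change, so the expectation rests only on the spread of the three compounds and has to stay wide. The estimated step of a 1.3-fold lower number from compound 2 to compound 4 (0.11 log units; within the scatter) is expected to stay within the scatter, with a slight lean toward a lower number. For compound 4 the expected value is 3 ug/mL in a range from 0.8 ug/mL to 10 ug/mL as estimated here.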

Compound 4, concentration for half-maximal effect: 4.6 ug/mL
For compound 4 the middle estimate is 1.5-fold (0.19 log units) below the measured one; measured number inside the range.
By their numbers in this assay, from the lowest: compound 1; then compounds 2 and 4 (each within the scatter of the next). At a limit, above all of these: compound 3.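

Going by these compounds alone, with this pair, the position two ring bonds from the ring oxygen is isolated for the first time: in this assay, bromomethyl in place of ethoxycarbonyl gives a 1.2-fold higher number from compound 2 to compound 4 (0.07 log units; within the scatter). At this carbon, then, a group with no hydrogen-bond acceptors and a group that has them cannot be told apart by this read-out, at least on this shared core and in this one pair. None of the information shown here accounts for this result.

From the compounds shown here alone, whether an aminomethyl group, a primary amide or a longer alkyl chain at this carbon would also stay within the scatter of compound 2 remains open. Going by these compounds, the other compounds differ from these two in more than one place, so it is also open whether the same swap would give a similar step on a different core.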